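Quinoline ether amides: lipophilicity notes before compound 4

This account rests on a few compounds, and the source may have more. Where it says the series, first, only, none or still open, it means among the compounds named here.

Three compounds of the series have a number in a physicochemical assay for lipophilicity, read by HPLC, in phosphate buffer, measured as chromatographic lipophilicity, at pH 7.4; on this read-out higher numbers stand for higher lipophilicity and lower numbers for lower lipophilicity. Compound 1 `COc1ccc2nc(C(F)(F)F)cc(OCC(=O)Nc3cc(C)cc(C)c3)c2c1` gives 7.02. Compound 3 `COc1ccc2nc(C)cc(OCC(=O)Nc3cc(OC)c(Cl)cc3OC)c2c1` gives 5.8. Compound 2 `COc1ccc2nc(C)cc(OCC(=O)NCc3cc(C)cc(C)c3)c2c1` gives 5.25, the lowest of the three numbers: the value of compound 3 sits above it by an amount beyond the scatter, and the value of compound 1 by a larger amount, also beyond the scatter. Among the measured compounds shown here, no pair of these three differs in one place only, so no single step between measured compounds is available.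

Compound 4 `COc1ccc2nc(C)cc(OCC(=O)Nc3ccncc3)c2c1` is the next compound to be measured in this assay . It differs from compound 2 in one place: pyridin-4-yl in place of 3,5-dimethylbenzyl on an amide-type nitrogen. Nine heavy atoms, all carbon, leave and six enter, one of them nitrogen carrying one hydrogen-bond acceptor. Given the value of compound 2 5.25 as the starting point, a downward step is expected, well beyond the scatter, estimated at a number 1.75 log units lower from compound 2 to compound 4 (beyond the scatter). For compound 4 the estimate in this assay is 3.5, expected within 2.8 to 4.3.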

Compound 4, distribution coefficient: 2.5
Compound 4: middle estimate off by 1.00 log units, on the high side; the measured number lies below the stated range.
By their numbers in this assay, from the lowest: compound 4; then compound 2; then compound 3; then compound 1.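

Among the compounds shown here, the first single-place step shows that, in this assay, the group on the amide-type nitrogen can by itself carry a large change: pyridin-4-yl in place of 3,5-dimethylbenzyl gives a number 2.75 log units lower from compound 2 to compound 4 (beyond the scatter). With the shared core and its other groups held constant, this change alone places compound 4 under compound 2, beyond the scatter. No measurement at hand accounts for the size of this step.

The step combines a smaller group with a ring nitrogen, and the compounds shown do not separate these two parts of the change. A phenyl or a pyridin-4-ylmethyl group on the same nitrogen would divide the step between the ring atom and the rest of the substituent.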